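This account rests on a few compounds, and the source may have more. Where it says the series, first, only, none or still open, it means among the compounds named here.

Measured so far in a functional assay on SGC-7901 cells (Homo sapiens) for cytotoxicity, read by MTT assay, with a stated time of 48 h; on this read-out higher numbers stand for weaker inhibition and lower numbers for stronger inhibition:
Compound 1 `Cc1ccc(-c2nnc(SCCn3c([N+](=O)[O-])cnc3C)o2)cc1`: 12500 nM
Compound 2 `COc1ccccc1-c1nnc(SCCn2c([N+](=O)[O-])cnc2C)o1`: 30500 nM
Compound 3 `Cc1ncc([N+](=O)[O-])n1CCSc1nnc(-c2ccccn2)o1`: 30000 nM

Compound 3, at 30000 nM, shares the high end of this small set with compound 2, and the two are separated only by a 1.0-fold lower number from compound 2 to compound 3 (0.01 log units; within the scatter). Compound 1 holds the lowest number, with a 2.4-fold higher number from compound 1 to compound 3 (0.38 log units; beyond the scatter) and a 2.4-fold higher number from compound 1 to compound 2 (0.39 log units; beyond the scatter) setting it apart from the other two.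

The next compound, compound 4 `Cc1ncc([N+](=O)[O-])n1CCSc1nnc(-c2ccc(N)nc2)o1`, carries 6-aminopyridin-3-yl in place of pyridin-2-yl, on an aromatic carbon of the five-membered aromatic ring with 2 nitrogen and 1 oxygen: 6-aminopyridin-3-yl in place of pyridin-2-yl on an aromatic carbon. All three measured steps change the group on this same aromatic carbon, so all three bear on it, though none of them introduces the entering group. Two of them were modest and one lay within the scatter. On that evidence, no step beyond the scatter is expected in this assay, with only a slight lean towards a lower number, since compound 1 shows that this group can give 12500 nM. The estimate means a 1.4-fold lower number from compound 3 to compound 4 (0.15 log units; within the scatter). Compound 4 is expected at 21000 nM, with an estimated range of 9000 nM to 50000 nM.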

Compound 4, half-maximal inhibitory concentration: 30900 nM
Estimate against measurement, compound 4: 1.5-fold (0.17 log units) below; measured number inside the range.
By their numbers in this assay, from the lowest: compound 1; then compounds 3, 2 and 4 (each within the scatter of the next).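

In this assay, 6-aminopyridin-3-yl on the aromatic carbon of the five-membered aromatic ring gives a 1.0-fold higher number from compound 3 to compound 4 (0.01 log units; within the scatter) and, against the 2-methoxyphenyl group, a 1.0-fold higher number from compound 2 to compound 4 (0.01 log units; within the scatter) so compounds 2, 3 and 4 now form a level group. Within the data shown here, the entering group brings a hydrogen-bond donor that pyridin-2-yl lacks, and here that exchange produces no step beyond the scatter, while only 4-methylphenyl stands apart, with a 2.5-fold higher number from compound 1 to compound 4 (0.39 log units; beyond the scatter) as the one new step of any size and compound 1 as the exception to the level group. Nothing available accounts for this flat result or for the separate place of compound 1.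

The compounds shown leave open how much the amine itself contributes, since the same pyridine attached in the same way but without its amine is absent from this set, and the amine's effect cannot be separated from that of the changed ring attachment. They also leave open whether the methyl group of compound 1 matters at all, which an unsubstituted phenyl, or a methoxy group in place of that methyl, would help to settle.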